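The compounds below may be only part of what the source reports. "The series", "measured", "known", "first", "only" and "open" are said of these compounds alone.

Compound 1, `Cc1ccccc1/C=C/c1ncc([N+](=O)[O-])n1C`, gives 93300 nM in an ADME assay on HeLa cells (Homo sapiens) for cytotoxicity, read by resazurin assay, with a stated time of 2 days; a lower number here means a stronger inhibitor, a higher number a weaker inhibitor. Compound 2, `Cn1c([N+](=O)[O-])cnc1/C=C/c1ccccc1Br`, gives 72400 nM in this assay. The step between them, a 1.3-fold lower number from compound 1 to compound 2 (0.11 log units; within the scatter), comes with the change (bromo in place of methyl on an aromatic carbon).

Compound 3, `Cc1ccc(CCc2ncc([N+](=O)[O-])n2C)cc1`, reaches only a limit in this assay, > 100000 nM. Compound 3 sits at the limit of > 100000 nM in this assay, at which 1 of the 3 values shown sits. How the core of compound 3 differs from the core of compound 1 is not broken down here.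

Compound 4, `Cn1c([N+](=O)[O-])cnc1CCc1ccc(Br)cc1`, is not yet measured in this assay. From compound 3 it differs by bromo in place of methyl on an aromatic carbon. This is the same kind of change as that from compound 1 to compound 2, but the place differs: in the measured pair the entering bromo sits ortho to a large group, whereas in compound 4 it sits para to a large group.

For compound 4 the step that the limit leaves unreadable from compound 3 to compound 4 is expected in this assay. This expectation rests on the measured step of a 1.3-fold lower number from compound 1 to compound 2 (0.11 log units; within the scatter), which lies within the scatter. Compound 4 is estimated at 120000 nM, with a range from 60000 nM to 250000 nM, and a limit rather than a number is likely.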

Compound 4, half-maximal inhibitory concentration: 97700 nM
Estimate against measurement, compound 4: 1.2-fold (0.09 log units) above, within the range that was stated.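

Bromo in place of methyl on an aromatic carbon can now be set side by side on two cores in this assay, and the comparison stands as follows: the same change on two cores in this assay, a 1.3-fold lower number (0.11 log units; within the scatter) from compound 1 to compound 2 and an at least 1.0-fold lower number (0.01 log units; that floor lies within the scatter) from compound 3 to compound 4; the limit leaves it open whether they differ

The new reading, an at least 1.0-fold lower number from compound 3 to compound 4 (0.01 log units; that floor lies within the scatter), is a floor and not a size of the step. Neither core shows a step beyond the scatter, which fits a change that carries across the two cores with little effect on the number, but the step on the core of compound 3 could still be larger than its floor, and the data therefore do not establish that the two cores respond alike.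

The compounds shown leave open how the series reads in this cytotoxicity measure with an amine or a carboxylic acid on the aromatic ring, or with a longer chain as the linker. From the compounds shown here alone, also open in this assay is whether bromo in place of methyl reads the same at other places on the aromatic ring.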